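Shifting one hydroxyl from 2-hydroxyphenyl to 4-hydroxyphenyl

A few compounds are considered here, and "the series" means these few. Any claim that something is new, unique, unknown or untested is made for them only; others in the source may bear on it.

Compound 2 `Oc1ccccc1-c1cc(-c2ccc(C(F)(F)F)cc2)cc(-c2ccccc2O)n1` carries two 2-hydroxyphenyl groups and one 4-(trifluoromethyl)phenyl group on the shared core. In a functional assay on HeLa cells (Homo sapiens) for inhibition (on this read-out higher numbers stand for weaker inhibition and lower numbers for stronger inhibition), compound 2 gives only a limit, > 50000 nM. Compound 1 `Oc1ccccc1-c1cc(-c2ccccc2F)cc(-c2ccccc2O)n1` differs by a 2-fluorophenyl group where compound 2 has the 4-(trifluoromethyl)phenyl group. In this assay compound 1 also gives only a limit, > 50000 nM. The step that the two limits leave unreadable from compound 1 to compound 2 therefore has no readable size. Among the compounds with values here, both measured values sit at the limit of > 50000 nM in this assay, at which 2 of the 2 values shown sit, so no step so far has a known size.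

Compound 3 `Oc1ccc(-c2cc(-c3ccc(C(F)(F)F)cc3)cc(-c3ccccc3O)n2)cc1` is the next change: 4-hydroxyphenyl in place of 2-hydroxyphenyl on an aromatic carbon. Within the data shown here, no measured step bears on this change; the single measured step concerns the other arm of the core and is itself unreadable. With compound 2 resting at a limit and nothing pointing to a gain, the working expectation is that compound 3 stays at or near that limit in this assay. The step of a number no higher from compound 2 to compound 3 (the limit leaves the size open) is expected to be no larger than the scatter. Compound 3 is estimated at 50000 nM, with a range from 10000 nM to 200000 nM, most likely reported again as a limit.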

Compound 3, half-maximal inhibitory concentration: > 50000 nM
Compound 3 gave a limit, no number; the forecaster's own chance of this, stated with the estimate: 80%; the middle value lies on the limit itself.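

In this assay compound 3 gives > 50000 nM, a limit and not a number. Within the data shown here, compound 2 also rests at a limit, so no step from compound 2 to compound 3 can be read. The compounds shown leave open which groups on the shared core, if any, give a readable inhibition value: the limit of > 50000 nM in this assay, at which 3 of the 3 values shown sit.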